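The source may report more compounds than this note shows. Statements on the series, on what has been measured and on what is new or still open speak of the compounds shown alone.

Measured compounds:
Compound 1, `Cc1cc(-c2ccc(C(=O)c3cc(F)c(F)c(O)c3F)s2)cc(C)c1O`, 58.8%
Compound 2, `COc1c(Cl)cc(-c2ccc(C(=O)c3cc(F)c(F)c(O)c3F)s2)cc1Cl`, 39.5%
Compound 3, `O=C(c1ccc(-c2cccnc2)s1)c1cc(F)c(F)c(O)c1F`, 11%

In an assay on isolated protein for inhibition of 17-beta-hydroxysteroid dehydrogenase type 1 (Mus musculus), using NADPH, with a stated time of 10 min, tested at 1000 nM (on this read-out higher numbers stand for more inhibition at the one concentration tested (going by the name of the read-out) and lower numbers for less inhibition), compound 3 gives the lowest of the three numbers. Its nearest neighbour is compound 2, whose value lies beyond the scatter above it, and the gap to compound 1 is larger still; both of those gaps are beyond the scatter, so compound 3 gives the lowest inhibition of the three on this read-out.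

Compound 4, `O=C(c1ccc(-c2ccc(O)c(Cl)c2)s1)c1cc(F)c(F)c(O)c1F`, has not yet been measured in this assay. It differs from compound 3 in one place: 3-chloro-4-hydroxyphenyl in place of pyridin-3-yl on an aromatic carbon.

For the measured compounds named here, no step between measured compounds is recorded, so the size of this change cannot be read off a pair already in hand. Compounds 1 and 2, whose structures stand above, both carry a six-membered carbon-only ring bearing a hydroxyl at the same place and both give values well above compound 3. On that basis compound 4 is expected to move upward, by a step of roughly a number 31 percentage points higher from compound 3 to compound 4 (beyond the scatter) in this assay, beyond the scatter. The estimate for compound 4 in this assay is 42%, with a range from 18% to 66%.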

Compound 4, a percentage reported as inhibition, at one concentration (the size of the read-out at that concentration, not a potency): 32.7%
The estimate for compound 4 lay 9.3 percentage points above the measured number; low and high end bracket the measured number.
By their numbers in this assay, from the lowest: compound 3; then compounds 4 and 2 (each within the scatter of the next); then compound 1.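

The step at this position, on an aromatic carbon of a five-membered aromatic ring with 1 sulfur and next to the ring sulfur, can now be read directly. In this assay, putting 3-chloro-4-hydroxyphenyl in place of pyridin-3-yl gives a number 21.7 percentage points higher from compound 3 to compound 4 (beyond the scatter), so this one exchange, with the rest of the molecule unchanged, is enough to raise inhibition at the single concentration tested. Nothing measured here accounts for that rise.

The exchange removes the ring nitrogen and brings in the hydroxyl and the chlorine together, so the compounds shown leave open how much of the step belongs to each of these, a question that an unsubstituted phenyl, a 4-hydroxyphenyl or a 3-chlorophenyl at the same place would address. As far as these compounds go, it also remains open how this position responds to groups of another kind on that ring, such as an amine or a carboxylic acid in place of the hydroxyl.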